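Swapping an aromatic amide for a difluorocyclohexyl group

The source may hold more compounds than are shown below. What is called first, only, known or untested is meant among the compounds shown, and "the series" means these compounds.

Measured compounds:
compound 1 `COc1cccc(OC)c1C(=O)Nc1c[nH]nc1C(=O)NC1CC1`, > 50000 nM
compound 2 `CO[C@H]1CC[C@H](NC(=O)c2n[nH]cc2NC(=O)c2cc3ccccn3n2)CC1`, 1000 nM
compound 3 `COc1cccc(OC)c1C(=O)Nc1c[nH]nc1C(=O)N[C@H]1CC[C@H](OC)CC1`, 31000 nM

In an ADME assay on MRC5 cells (Homo sapiens) for inhibition, with a stated time of 72 h (on this read-out higher numbers stand for an effect only at larger amounts of compound and lower numbers for an effect already at smaller amounts), compound 2 gives 1000 nM, the lowest of the numbers shown. Compound 3 gives 31000 nM in this assay. The value of compound 1 in this assay is a limit (the limit of > 50000 nM in this assay, at which 1 of the 3 values shown sits), not a number. Among the compounds with values here, the only step measured, an at least 1.6-fold lower number from compound 1 to compound 3 (0.20 log units; that floor lies within the scatter), concerns the amide-type nitrogen, not the carbonyl side, so it does not bear on the change now in question. Compound 4 `CO[C@H]1CC[C@H](NC(=O)c2n[nH]cc2NC(=O)C2CCC(F)(F)CC2)CC1` differs from compound 2 as follows: a group of 8 heavy atoms (6 carbon, 2 fluorine; one six-membered non-aromatic ring of carbon only) in place of a group of 9 heavy atoms (7 carbon, 2 nitrogen; one five-membered aromatic ring with 2 hetero atoms, one six-membered aromatic ring with 1 hetero atom), on a carbonyl carbon. Compounds 2 and 3, which differ at the same carbonyl, show a wide gap, so a shift toward higher numbers is expected, a 10-fold higher number from compound 2 to compound 4 (1.00 log units; beyond the scatter). Compound 4 is estimated at 10000 nM, between 3000 nM and 40000 nM.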

Compound 4, half-maximal effective concentration: > 50000 nM
Compound 4: no number, only a limit (the forecaster's own chance of this, stated with the estimate: 20%); middle value at least 5.0-fold (0.69 log units) away from the limit.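

At the carbonyl carbon, 4,4-difluorocyclohexyl in place of the aromatic group gives an at least 50-fold higher number from compound 2 to compound 4 (1.69 log units; beyond the scatter) in this assay. This makes the carbonyl side a place where a single change moves the read-out by a large step, whereas the floor of the earlier step on the amide-type nitrogen lay within the scatter. Compound 4 gives a limit, not a number: the limit of > 50000 nM in this assay, at which 2 of the 4 values shown sit.

On these data alone, the true size of the step therefore stays open. So does what plain cyclohexyl, without fluorine, or a cyclohexyl ring carrying an amine would give on this carbonyl.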